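Series notes: aryl hydrazone swap on the shared core

The source may report more compounds than this note shows. Statements on the series, on what has been measured and on what is new or still open speak of the compounds shown alone.

Measured so far:
- compound 1, `COc1ccc(OC)c(/C=N/NC(=O)Nc2ccc(Oc3ccnc(-c4nncn4CCN(C)C)c3)c(F)c2)c1`: 1510 nM
- compound 2, `CN(C)CCn1cnnc1-c1cc(Oc2ccc(NC(=O)N/N=C/c3cccc(Cl)c3Cl)cc2F)ccn1`: 51 nM

In a functional assay on MKN-45 cells (Homo sapiens) for cytotoxicity, read by MTT assay, with a stated time of 72 h (a higher number here means a weaker inhibitor, a lower number a stronger inhibitor), compound 2 gives the lowest of the two numbers; its nearest neighbour is compound 1, and the step of a 30-fold lower number from compound 1 to compound 2 (1.47 log units; beyond the scatter) is large. Both compounds share the same core and differ only in the aryl group on the carbon with a double bond to nitrogen.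

Compound 3, `CN(C)CCn1cnnc1-c1cc(Oc2ccc(NC(=O)N/N=C/c3ccc(O)cc3O)cc2F)ccn1`, is not yet measured. It carries the change (2,4-dihydroxyphenyl in place of 2,3-dichlorophenyl on a carbon with a double bond to nitrogen). Among the compounds with values here, the only measured step that bears on it is a 30-fold lower number from compound 1 to compound 2 (1.47 log units; beyond the scatter), which shows that swapping the aryl group at this position alone can move the number by a large amount, and that the 2,3-dichlorophenyl of compound 2 accompanied the lowest number seen. Within the data shown here, compound 3 removes that group, so a step back toward a higher number, beyond the scatter, is the expectation, though with only one comparison its size is uncertain.

For compound 3 the number in this assay is estimated at 600 nM, within 150 nM to 3000 nM, meaning an expected step of a 12-fold higher number from compound 2 to compound 3 (1.07 log units; beyond the scatter).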

Compound 3, half-maximal inhibitory concentration: 2860 nM
Compound 3: the middle estimate sits 4.8-fold (0.68 log units) below what was measured; the range from low to high includes it.
By their numbers in this assay, from the lowest: compound 2; then compounds 1 and 3 (each within the scatter of the next).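

In this assay the step from 2,3-dichlorophenyl to 2,4-dihydroxyphenyl on a carbon with a double bond to nitrogen gives a 56-fold higher number from compound 2 to compound 3 (1.75 log units; beyond the scatter) on an unchanged shared core, so the low number of compound 2 does not carry over to this second replacement of its aryl group. The other new step, a 1.9-fold higher number from compound 1 to compound 3 (0.28 log units; within the scatter), leaves the 2,5-dimethoxyphenyl and 2,4-dihydroxyphenyl compounds unseparated, even though these two aryl groups differ in their oxygen-bearing groups and in where those groups sit, which leaves compound 2 alone with the lowest number among the three. No measurement at hand offers an explanation for the gap between compound 2 and the other two compounds.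

The compounds shown leave open whether the low number depends on having two chlorines, since an unsubstituted phenyl, a monochlorophenyl and a dibromophenyl are absent from this set. They also leave open how an aryl group bearing methyl groups, an amine or a carboxylic acid would behave at this position, and whether the large step seen here would recur on a different core.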